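Chloro substitution across two cores: notes toward compound 4

This account rests on a few compounds, and the source may have more. Where it says the series, first, only, none or still open, it means among the compounds named here.

Compound 1 `N#Cc1c(-c2ccccc2)nc2c(c(-c3ccccc3)nn2-c2ccccc2)c1-c1ccc(N2CCCCC2)cc1` and compound 2 `N#Cc1c(-c2ccc(Cl)cc2)nc2c(c(-c3ccccc3)nn2-c2ccccc2)c1-c1ccc(N2CCCCC2)cc1` share one core; compound 3 `O=C(C=CNc1cc(-c2ccccc2)nn1-c1ccccc1)c1ccccc1` and the unmeasured compound 4 `O=C(C=CNc1cc(-c2ccccc2)nn1-c1ccccc1)c1ccc(Cl)cc1` share another. The difference between the two cores is not broken down here.

In a functional assay on HepG2 cells (Homo sapiens) for inhibition, read by MTT assay, with a stated time of 48 h (on this read-out higher numbers stand for weaker inhibition and lower numbers for stronger inhibition), compound 1 gives 30900 nM. Compound 2 gives 3210 nM in this assay. The change between them, (chloro in place of hydrogen on an aromatic carbon), made a step of a 9.6-fold lower number from compound 1 to compound 2 (0.98 log units; beyond the scatter). Compound 3 gives 2660 nM in this assay; its number and that of compound 2 lie within the scatter of each other, while compound 1 sits well apart from both.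

Compound 4 carries the same change on the other core: chloro in place of hydrogen on an aromatic carbon. The same kind of change is the one measured once, from compound 1 to compound 2, and it occurs only twice among the four compounds shown, so there is no second measured step to test whether it repeats on the core of compound 3. On that single precedent, compound 4 is expected to land at a lower number than compound 3, with a step of about a 3.0-fold lower number from compound 3 to compound 4 (0.47 log units; beyond the scatter), rather than the full size of the step from compound 1 to compound 2, because a 9.6-fold lower number from compound 1 to compound 2 (0.98 log units; beyond the scatter) was measured on a different core. The estimate for compound 4 in this assay is 900 nM, with a plausible range from 250 nM to 3000 nM.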

Compound 4, half-maximal inhibitory concentration: 41200 nM
Beside the measured number, compound 4's estimate is 46-fold (1.66 log units) below it; measured number outside the range, above it.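

In this assay, chloro in place of hydrogen on an aromatic carbon, here phenyl to 4-chlorophenyl as part of benzoyl to (4-chlorophenyl)carbonyl, gave a 15-fold higher number from compound 3 to compound 4 (1.19 log units; beyond the scatter), so the change did not carry over from one core to the other and the two steps run in opposite directions: the same change on two cores in this assay, a 9.6-fold lower number (0.98 log units; beyond the scatter) from compound 1 to compound 2 and a 15-fold higher number (1.19 log units; beyond the scatter) from compound 3 to compound 4, 150-fold (2.17 log units) apart, beyond the scatter of two such steps

For this series, a step measured on the core of compound 1 therefore gave no reliable guide to either the direction or the size of the step on the core of compound 3. The result does not show why the steps differ, and with a single pair on each core it cannot separate the part played by the core from the part played by where the 4-chlorophenyl group is attached, nor does it show how either step would hold up on a further pair.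

The compounds shown leave open whether the rise on the core of compound 3 is particular to chloro or would also appear with fluoro, methoxy or a dimethylamino group in the same place. They also leave open whether any such group would give matching steps on the two cores, which only further pairs carrying the same group on both cores could settle.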